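Changing the Amine Side of Compound 2

The source may report more compounds than this note shows. Statements on the series, on what has been measured and on what is new or still open speak of the compounds shown alone.

Measured compounds:
compound 1 `CCCCNC(=O)OCC(O)Cn1cc(CN(C)CCC(C)C)nn1` — 24%
compound 2 `CC(C)CCN(C)Cc1cn(CC(O)COC(=O)c2ccccc2)nn1` — 0%
compound 3 `CC(C)CCN(C)Cc1cn(CC(O)COC(=O)C2CCCCC2)nn1` — 0%

In an assay on nucleic acid for inhibition of Nucleic Acid, read by fluorescence, tested at 100 uM (on this read-out lower numbers stand for less inhibition and higher numbers for more inhibition at the one concentration tested (going by the name of the read-out)), compound 2 gives 0%. It stands level with compound 3 at the digits shown, and the two together are the lowest of the three numbers; the only compound beyond the scatter is compound 1, which gives 24%, so that a number 24 percentage points lower from compound 1 to compound 2 (beyond the scatter). The measured steps all change the group on the carbonyl carbon: a number 24 percentage points lower from compound 1 to compound 3 (beyond the scatter) and no change at the digits printed from compound 2 to compound 3 (within the scatter).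

Compound 4 `CCCCN(CCCC)Cc1cn(CC(O)COC(=O)c2ccccc2)nn1` is not yet measured in this assay. It differs from compound 2 as follows: dibutylamino in place of isopentyl(methyl)amino on a saturated chain carbon bound to an aromatic carbon. Within the data shown here, none of the measured steps touches this part of the molecule, so no measured step bears directly on it. Among the measured compounds shown here, the only guide is that compound 2 and compound 3 share the same amine and both sit at the bottom of the range. On that basis compound 4 is expected to stay near the floor, with a number 5 percentage points higher from compound 2 to compound 4 (within the scatter). The estimate for compound 4 is 5%, expected to fall between 0% and 25%.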

Compound 4, a percentage reported as inhibition, at one concentration (the size of the read-out at that concentration, not a potency): 12%
Beside the measured number, compound 4's estimate is 7 percentage points below it; the measured number falls inside the stated range.
By their numbers in this assay, from the lowest: compounds 2 and 3 (each within the scatter of the next); then compound 4; then compound 1.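

The amine side of the molecule turns out to affect the read-out in this assay: with the benzoyl ester side held constant, dibutylamino in place of isopentyl(methyl)amino gives a number 12 percentage points higher from compound 2 to compound 4 (beyond the scatter). Among these compounds, this is the first measured change on a saturated chain carbon bound to an aromatic carbon, as the earlier steps all changed the group on the carbonyl carbon. Nothing shown here explains the rise.

On these data alone, it remains open whether the same amine change would give a similar step with the butylamino or cyclohexyl group on the carbonyl carbon. Also unresolved is how a cyclic amine such as piperidine or morpholine would read in place of dibutylamino.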